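This account rests on a few compounds, and the source may have more. Where it says the series, first, only, none or still open, it means among the compounds named here.

Of the compounds shown here, two have so far been measured in an assay on HeLa cells with Bile acid receptor (Homo sapiens) as the target, read by a luciferase reporter, with a stated time of 24 h; on this read-out higher numbers stand for an effect only at larger amounts of compound and lower numbers for an effect already at smaller amounts. Compound 1 `CC(C)(C)c1ccc(C(=O)NCc2ccc(NS(C)(=O)=O)cc2)cc1` gives 44 nM in this assay, and compound 2 `CC(=O)Nc1ccc(CNC(=O)c2ccc(C(C)(C)C)cc2)cc1` gives 2900 nM. Among the measured compounds shown here, the one recorded single-point step, a 66-fold higher number from compound 1 to compound 2 (1.82 log units; beyond the scatter), came from placing acetyl in place of methylsulfonyl on a nitrogen on an aromatic ring, and it shows how strongly the read-out responds to a change at that spot. Compound 2 therefore stands at the highest of the two numbers, with compound 1 as its nearest neighbour.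

Compound 3 `CC(C)(C)c1ccc(C(=O)NCc2ccc(CCC(=O)O)cc2)cc1` has not yet been measured. It differs from compound 2 by 2-carboxyethyl in place of acetamido on an aromatic carbon. For the measured compounds named here, no measured step involves a 2-carboxyethyl group, so the step between compounds 1 and 2 bears on this change only by showing that alterations at that spot can be large; it gives no direction. A step of roughly a 1.9-fold lower number from compound 2 to compound 3 (0.29 log units; within the scatter) is expected, with wide uncertainty. Compound 3 is estimated to give 1500 nM, in a range from 200 nM to 10000 nM.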

Compound 3, half-maximal effective concentration: 350 nM
Compound 3: middle estimate off by 4.3-fold (0.63 log units), on the high side; measured number inside the range.
By their numbers in this assay, from the lowest: compound 1; then compound 3; then compound 2.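

The step of an 8.3-fold lower number from compound 2 to compound 3 (0.92 log units; beyond the scatter) for 2-carboxyethyl in place of acetamido shows that a group with no nitrogen on this aromatic carbon can still give a clearly lower number than compound 2. The step of an 8.0-fold higher number from compound 1 to compound 3 (0.90 log units; beyond the scatter) for 2-carboxyethyl in place of methanesulfonamido shows that this chain does not match compound 1, so among these three compounds the position separates all three groups, with compound 3 in the middle. Nothing given here accounts for this order.

The compounds shown leave open how a shorter carboxymethyl chain, a longer 3-carboxypropyl chain, a methyl ester of the acid or a primary amide would compare on this carbon. They also leave open how an ethylsulfonyl group on the nitrogen would compare with the methylsulfonyl group of compound 1.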